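The compounds below may be only part of what the source reports. "The series", "measured", "known", "first", "only" and "open" are said of these compounds alone.

Measured so far:
- compound 1, `Cc1ccccc1C(=O)OC(CCN(C)C)c1ccc(Cl)cc1`: 126%
- compound 2, `Cc1ccc(C)c(C(=O)OC(CCN(C)C)c2ccc(Cl)cc2)c1`: 86%
- compound 3, `Cc1ccc(C)c(C(=O)NC(CCN(C)C)c2ccc(Cl)cc2)c1`: 164%

In an assay on NIH3T3 cells with Urotensin-2 receptor (Homo sapiens) as the target (a lower number here means a smaller maximal response, a higher number a larger maximal response), compound 1 gives 126%, compound 2 gives 86% and compound 3 gives 164%. Compound 3 stands highest of the three, and each of its gaps to the other two lies beyond the scatter.

Compound 1 and compound 2 differ in one place only:

methyl in place of hydrogen on an aromatic carbon

This single added methyl made a large step in this assay: a number 40 percentage points lower from compound 1 to compound 2 (beyond the scatter).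

Compound 4, `Cc1cc(C)c(C(=O)NC(CCN(C)C)c2ccc(Cl)cc2)cc1C`, has not yet been measured. It is built on the core of compound 3; the difference between that core and the core of compound 1 is not broken down here. Compound 4 differs from compound 3 in one place:

methyl in place of hydrogen on an aromatic carbon

Going by the values given here, it is the same kind of change as the one from compound 1 to compound 2, but not the same: in compound 2 the new methyl sits meta to a large group and para to a methyl group, whereas in compound 4 it sits ortho to a methyl group, meta to a methyl group and para to a large group.

Among the compounds with values here, on the strength of the step seen in this assay from compound 1 to compound 2, a number 40 percentage points lower from compound 1 to compound 2 (beyond the scatter), a downward step of comparable size is expected here as well, though with wide uncertainty because the surroundings of the new methyl differ and only one earlier example exists. The expected step is a number 39 percentage points lower from compound 3 to compound 4 (beyond the scatter). For compound 4 the estimate in this assay is 125%, within a range from 85% to 165%.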

Compound 4, largest response reached (reported as efficacy), in percent of the reference or control that the assay uses: 159%
Beside the measured number, compound 4's estimate is 34 percentage points below it, and the stated range covers the measured number.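

In this assay, the added methyl on the aromatic ring now gives a number 5 percentage points lower from compound 3 to compound 4 (within the scatter), so on this core the maximal response cannot be told apart before and after the change. Set beside the earlier step, the same kind of change does not carry a fixed size from one core to the other: the same change on two cores in this assay, a number 40 percentage points lower (beyond the scatter) from compound 1 to compound 2 and a number 5 percentage points lower (within the scatter) from compound 3 to compound 4, 35 percentage points apart, beyond the scatter of two such steps. This shows that a step seen on one core cannot simply be transferred to another in this series, but it does not show what sets the size of the step, as the two pairs differ both in their core and in where the new methyl sits, and two pairs give no general rule.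

The compounds shown leave open whether the gap follows the core or the place of the methyl, and a matched pair with the new methyl in the same place on both cores would separate the two. They also leave open whether a different group in that place, such as an ethyl, a methoxy or a fluorine, would behave as the methyl does on either core.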